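Removing the trifluoromethyl: from compound 1 to compound 4

The source may report more compounds than this note shows. Statements on the series, on what has been measured and on what is new or still open speak of the compounds shown alone.

Measured so far:
compound 1 `C/C(=N\NC(=O)c1ccc(C(F)(F)F)cc1)c1cnccn1` — 2090 nM
compound 2 `C/C(=N\NC(=O)c1cccc(Br)c1)c1cnccn1` — 3120 nM
compound 3 `C/C(=N\NC(=O)c1ccc(Br)cc1)c1cnccn1` — 2940 nM

In an ADME assay on MRC5 cells (Homo sapiens) for antiproliferative activity, read by MTT assay (a lower number here means a stronger inhibitor, a higher number a weaker inhibitor), compound 1 holds the lowest of the three numbers, yet the gap to compound 3 is a 1.4-fold higher number from compound 1 to compound 3 (0.15 log units; within the scatter), and compound 2 also sits within the scatter of compound 1, so the three are not separable.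

Compound 4 `C/C(=N\NC(=O)c1ccccc1)c1cnccn1` differs from compound 1 by hydrogen in place of trifluoromethyl on an aromatic carbon. Within the data shown here, the only step that bears on it is a 1.4-fold higher number from compound 1 to compound 3 (0.15 log units; within the scatter), a swap of one group for another at the same carbon, which left the number essentially unchanged. Among the measured compounds shown here, no measured step removes a group outright, so the expectation rests on that single swap: a step of a 1.3-fold higher number from compound 1 to compound 4 (0.13 log units; within the scatter) is expected, most likely a slight rise but within the scatter. Compound 4 is therefore estimated at 2800 nM, between 1400 nM and 6000 nM.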

Compound 4, half-maximal inhibitory concentration: 7040 nM
The estimate for compound 4 lay 2.5-fold (0.40 log units) below the measured number, and the stated range ends below it.
By their numbers in this assay, from the lowest: compounds 1, 3 and 2 (each within the scatter of the next); then compound 4.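

In this assay the loss of a substituent moves the number where the swap between substituents did not: hydrogen in place of trifluoromethyl gives a 3.4-fold higher number from compound 1 to compound 4 (0.53 log units; beyond the scatter) and hydrogen in place of bromo gives a 2.4-fold higher number from compound 3 to compound 4 (0.38 log units; beyond the scatter) and likewise a 2.3-fold higher number from compound 2 to compound 4 (0.35 log units; beyond the scatter) as modest steps. Trifluoromethyl and bromo remain inseparable, so among these compounds the presence of either group on the ring counts, not which one. Nothing measured here accounts for these steps.

Open, as far as these compounds go, is whether an amine, a methoxy group or a carboxylic acid at the same aromatic carbon would match compound 1 or fall with compound 4.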